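Methyl on the shared core: a small, repeated change

The source may report more compounds than this note shows. Statements on the series, on what has been measured and on what is new or still open speak of the compounds shown alone.

Of the compounds shown here, three of this set have been measured in a functional assay on MCF7 cells (Homo sapiens) for cytotoxicity, read by MTT assay, with a stated time of 72 h; on this read-out lower numbers stand for stronger inhibition and higher numbers for weaker inhibition. Compound 1 `O=C1CC(c2c(-c3ccc[nH]3)[nH]c3ccccc23)C(=O)N1` gives 35000 nM. Compound 3 `O=C1NC(=O)C(c2c(-n3cccn3)[nH]c3ccccc23)=C1Br` gives 27000 nM, and compound 2 `Cc1ccc2[nH]c(-n3cccn3)c(C3=C(Br)C(=O)NC3=O)c2c1` gives 15000 nM. Compound 2 arises from compound 3 by one change, (methyl in place of hydrogen on an aromatic carbon), and that change made a step of a 1.8-fold lower number from compound 3 to compound 2 (0.26 log units; within the scatter). How the core of compound 1 differs from that of compound 3 is not broken down here.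

Compound 4 `Cc1ccc2[nH]c(-c3ccc[nH]3)c(C3CC(=O)NC3=O)c2c1` has not yet been measured. It arises from compound 1 by methyl in place of hydrogen on an aromatic carbon, the same change in the same place. Because the earlier step was a 1.8-fold lower number from compound 3 to compound 2 (0.26 log units; within the scatter), a step of about a 1.8-fold lower number from compound 1 to compound 4 (0.24 log units; within the scatter) is expected from compound 1 to compound 4, and this rests on that single pair alone. Compound 4 is therefore estimated to give 20000 nM, likely between 8000 nM and 50000 nM.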

Compound 4, half-maximal inhibitory concentration: 29000 nM
The estimate for compound 4 lay 1.5-fold (0.16 log units) below the measured number, within the range that was stated.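

In this assay, among these compounds, the methyl in place of hydrogen on an aromatic carbon gave a 1.2-fold lower number from compound 1 to compound 4 (0.08 log units; within the scatter) and thus no step that can be told apart from repeat-measurement noise. Set beside the earlier step, the result on the two cores agrees: the same change on two cores in this assay, a 1.8-fold lower number (0.26 log units; within the scatter) from compound 3 to compound 2 and a 1.2-fold lower number (0.08 log units; within the scatter) from compound 1 to compound 4, 1.5-fold (0.17 log units) apart, within the scatter of two such steps. The change therefore carried from one core to the other without a detectable difference, yet both steps lie within the scatter, and two pairs cannot show that the methyl truly alters the number on either core or on any further core.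

The compounds shown leave open whether a different group at that same place, such as a chlorine atom, a methoxy group or an amine, would give a step beyond the scatter.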